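This account rests on a few compounds, and the source may have more. Where it says the series, first, only, none or still open, it means among the compounds named here.

Measured so far in an assay on LX2 cells for inhibition of COL1A1 promoter (Homo sapiens), read by a luciferase reporter, with a stated time of 24 h, tested at 20 uM; on this read-out lower numbers stand for a weaker effect and higher numbers for a stronger effect at the one concentration tested:

compound 1 `Cc1ccc(-n2cc(C(=O)Nc3cc(F)cc(F)c3)c(=O)c3ccc(N(C)C)nc32)cc1OCCCCCCC[N+]1(C)CCCC1`: 12.7%
compound 2 `Cc1ccc(-n2cc(C(=O)Nc3cc(F)cc(F)c3)c(=O)c3ccc(N(C)C)nc32)cc1OCCCCCCC[n+]1ccccc1`: 39.7%
compound 3 `CC[N+]1(CCCCCCCOc2cc(-n3cc(C(=O)Nc4cc(F)cc(F)c4)c(=O)c4ccc(N(C)C)nc43)ccc2C)CCCC1`: 57%

Compound 3 stands highest of the three numbers in this assay. Its nearest neighbour is compound 2, with a number 17.3 percentage points higher from compound 2 to compound 3 (beyond the scatter); its furthest is compound 1, with a number 44.3 percentage points higher from compound 1 to compound 3 (beyond the scatter). The third measured step, a number 27 percentage points higher from compound 1 to compound 2 (beyond the scatter), also lies beyond the scatter.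

Compound 4 `Cc1ccc(-n2cc(C(=O)Nc3cc(F)cc(F)c3)c(=O)c3ccc(N(C)C)nc32)cc1OCCCCCCC[N+](C)(C)C1CCCCC1` is not yet measured. It differs from compound 3 at the same place where all three measured steps sit: a group of 9 heavy atoms (8 carbon, 1 nitrogen; one six-membered non-aromatic ring of carbon only) in place of a group of 7 heavy atoms (6 carbon, 1 nitrogen; one five-membered non-aromatic ring with 1 hetero atom), on a saturated chain carbon, seven bonds along the chain from an oxygen on an aromatic ring.

All measured steps bear on this change, since each alters only the charged group at the chain end. Each moved the read-out beyond the scatter, and the two steps that added heavy atoms at this group, a number 44.3 percentage points higher from compound 1 to compound 3 (beyond the scatter) and a number 17.3 percentage points higher from compound 2 to compound 3 (beyond the scatter), both gave higher numbers. Among the measured compounds shown here, the group entering in compound 4 again carries more heavy atoms than the one leaving, so a rise is expected rather than a fall, though the new group has no measured counterpart and the step is estimated as modest at most. For compound 4 the expected step is a number 3 percentage points higher from compound 3 to compound 4 (within the scatter). Compound 4 is therefore estimated at 60% in this assay, within 40% to 78%.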

Compound 4, a percentage reported as inhibition, at one concentration (the size of the read-out at that concentration, not a potency): 32.3%
Beside the measured number, compound 4's estimate is 27.7 percentage points above it; the measured number lies below the stated range.
By their numbers in this assay, from the lowest: compound 1; then compounds 4 and 2 (each within the scatter of the next); then compound 3.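

In this assay, a larger group at the chain end does not by itself give a higher number: with the group bearing a six-membered non-aromatic ring of carbon only, the result is a number 24.7 percentage points lower from compound 3 to compound 4 (beyond the scatter), so compound 4 goes against the rise seen on reaching compound 3 from compound 1 and compound 2. This group still keeps part of the read-out, with a number 19.6 percentage points higher from compound 1 to compound 4 (beyond the scatter) and a number 7.4 percentage points lower from compound 2 to compound 4 (within the scatter), so at this position the outcome depends on the make-up of the charged group and not on its heavy-atom count alone. Nothing measured here explains these differences.

Going by these compounds, whether the ring or the substituents on the charged nitrogen govern the read-out remains open, and a trimethylammonium group or an ethyl-substituted piperidinium ring would bear on this. Also open, on these data alone, is how any of these groups behaves on a shorter or longer chain.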